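Crown ether esters: pyridin-3-yl acyl in place of cinnamoyl

The source may hold more compounds than are shown below. What is called first, only, known or untested is meant among the compounds shown, and "the series" means these compounds.

Compound 1 `O=C(/C=C/c1ccccc1)OCC1COCCOCCOCCOCCOCCO1` holds the lowest of the two numbers in hand: in a functional assay on SW1573 cells (Homo sapiens) for inhibition, read by sulforhodamine B assay, with a stated time of 48 h (a higher number here means a weaker inhibitor of growth, a lower number a stronger inhibitor of growth), compound 1 gives 48000 nM. Compound 2 `O=C(CCCCCc1ccccc1)OCC1COCCOCCOCCOCCOCCO1` gives 78000 nM, so a 1.6-fold higher number from compound 1 to compound 2 (0.21 log units; within the scatter). Compound 3 `CC/C=C/CC(=O)OCC1COCCOCCOCCOCCOCCO1` reaches only the assay limit, > 100000 nM. The step of an at least 2.0-fold higher number from compound 1 to compound 3 (0.31 log units; beyond the scatter) rests on (the limit of > 100000 nM in this assay, at which 1 of the 3 values shown sits). Compound 4 `O=C(OCC1COCCOCCOCCOCCOCCO1)c1cccnc1` differs from compound 1 in one place: pyridin-3-yl in place of 2-phenylethenyl on a carbonyl carbon, the same change read one bond further out being (2-phenylethenyl)carbonyl to (pyridin-3-yl)carbonyl. Both measured steps away from compound 1 raise the number, and the larger one removes the six-membered carbon ring, as this change does. A higher number is therefore expected in this assay, an expected 1.9-fold higher number from compound 1 to compound 4 (0.27 log units; within the scatter). Compound 4 is estimated at 90000 nM, within 40000 nM to 300000 nM, close to the limit.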

Compound 4, concentration for 50% growth inhibition: > 100000 nM
Compound 4 ended at the assay's limit; the forecaster's own chance of this, stated with the estimate: 45%; middle value at least 1.1-fold (0.04 log units) from the limit.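

In this assay, pyridin-3-yl on the carbonyl carbon gives an at least 2.0-fold higher number from compound 1 to compound 4 (0.31 log units; beyond the scatter), so keeping a six-membered aromatic ring at this position does not by itself hold the number of compound 1. The second readable step, an at least 1.2-fold higher number from compound 2 to compound 4 (0.10 log units; that floor lies within the scatter), does not separate that pair. The step between compound 3 and compound 4 cannot be read, and the value of compound 4 is a limit: the limit of > 100000 nM in this assay, at which 2 of the 4 values shown sit.

Still open, going by these compounds, is whether the ring nitrogen or the loss of the double bond accounts for the step. A phenyl group on the carbonyl carbon, or a 2-(pyridin-3-yl)ethenyl group, would separate the two.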